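This account rests on a few compounds, and the source may have more. Where it says the series, first, only, none or still open, it means among the compounds named here.

Within the data shown here, in a functional assay on HUVEC cells (Homo sapiens) for cytotoxicity, read by WST assay, with a stated time of 48 h (a higher number here means a weaker inhibitor, a lower number a stronger inhibitor), compound 1 (`O=C(NC(=S)Nc1cccc(-c2nc3ccccc3[nH]2)c1)c1ccc2c(c1)OCCO2`) gives 50 nM and holds the lowest of the two numbers so far, while compound 2 (`COc1ccc(C(=O)NC(=S)Nc2cccc(-c3nc4ccccc4[nH]3)c2)cc1OC`) gives 6000 nM in the same test. Compound 3 (`Cc1ccc(-c2nc3ccccc3[nH]2)cc1NC(=S)NC(=O)c1ccc2c(c1)OCCO2`) differs from compound 1 by a single change, methyl in place of hydrogen on an aromatic carbon. Among the measured compounds shown here, the only measured step is a 120-fold higher number from compound 1 to compound 2 (2.08 log units; beyond the scatter) and it sits at a different place in the molecule, so it bears on this methyl only indirectly, showing that one small edit moved the number a long way. Compound 1 at 50 nM is the low end of what has been seen, so a higher number seems more likely here, though by less than that step. The expected change is a 4.0-fold higher number from compound 1 to compound 3 (0.60 log units; beyond the scatter) as a rough estimate. For compound 3 the estimated value is 200 nM with an expected range from 40 nM to 2000 nM at this stage.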

Compound 3, half-maximal inhibitory concentration: 240 nM
Compound 3: middle estimate off by 1.2-fold (0.08 log units), on the low side; low and high end bracket the measured number.
By their numbers in this assay, from the lowest: compound 1; then compound 3; then compound 2.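

In this assay, placing one methyl on this aromatic carbon, ortho to a large group and para to the 1H-benzimidazol-2-yl group, gives a 4.8-fold higher number from compound 1 to compound 3 (0.68 log units; beyond the scatter) as the change in the number. This shows that the core of compound 1 is sensitive at this carbon as well as at the group on the carbonyl, where the earlier step was a 120-fold higher number from compound 1 to compound 2 (2.08 log units; beyond the scatter) in size. Even a single added carbon atom here moves the result beyond the usual scatter. No available evidence explains why this methyl has that effect. Going by these compounds, it remains open whether a fluorine atom, a methoxy group or a longer chain such as ethyl on this carbon would shift the number less or more. On these data alone, it also remains open whether the methyl would have a similar effect alongside the 3,4-dimethoxyphenyl group of compound 2.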